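Pyrimidine ester series: quinolinyl to dimethylpyrazolyl replacement

This account rests on a few compounds, and the source may have more. Where it says the series, first, only, none or still open, it means among the compounds named here.

Measured so far:
compound 1 `CCOC(=O)c1cnc(CC)nc1NN1C(=O)C=C(C)C1=O`: 10000 nM
compound 2 `CCOC(=O)c1cnc(-c2cnc3ccccc3c2)nc1NN1C(=O)C=C(C)C1=O`: 6000 nM

In a functional assay on Jurkat cells for inhibition of nuclear factor NF-kappa-B complex (Homo sapiens) (a higher number here means a weaker inhibitor, a lower number a stronger inhibitor), compound 1 gives 10000 nM and compound 2 gives 6000 nM. Among the compounds with values here, the only step on record, a 1.7-fold lower number from compound 1 to compound 2 (0.22 log units; within the scatter), is within the scatter, so compound 2 and compound 1 are not separated by these numbers; compound 2 stands at one end of two values that cannot be told apart.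

Compound 3 `CCOC(=O)c1cnc(-n2nc(C)cc2C)nc1NN1C(=O)C=C(C)C1=O` differs from compound 2 by 3,5-dimethyl-1H-pyrazol-1-yl in place of quinolin-3-yl on an aromatic carbon. Within the data shown here, no measured step involves a pyrazolyl group at this place. Among the measured compounds shown here, the one step that bears on it, a 1.7-fold lower number from compound 1 to compound 2 (0.22 log units; within the scatter), shows that swapping a small alkyl for a bicyclic aromatic group at this carbon moved the readout in this assay only within the scatter. On that basis a step of no more than the scatter is expected for a 1.2-fold higher number from compound 2 to compound 3 (0.07 log units; within the scatter), with no clear direction. Compound 3 is therefore estimated at 7000 nM, with a range from 2500 nM to 20000 nM.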

Compound 3, half-maximal inhibitory concentration: 10000 nM
Compound 3: middle estimate off by 1.4-fold (0.15 log units), on the low side, and the stated range covers the measured number.
By their numbers in this assay, from the lowest: compounds 2, 1 and 3 (each within the scatter of the next).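

In this assay putting 3,5-dimethyl-1H-pyrazol-1-yl in place of quinolin-3-yl gives a 1.7-fold higher number from compound 2 to compound 3 (0.22 log units; within the scatter) while putting it in place of ethyl gives no change at the digits printed from compound 1 to compound 3 (within the scatter) and so the new group is separated from neither earlier group. A five-membered aromatic ring with 2 hetero atoms now joins the ethyl and quinolin-3-yl groups at this carbon between two ring nitrogen atoms, and all three compounds lie within the scatter of one another. Nothing available explains this lack of separation.

Still open, going by these compounds, is whether any group at this carbon can move the number beyond the scatter, for example an amine, a carboxylic acid or a longer alkyl chain. Also open, on these data alone, is how a carboxylic acid in place of the ethoxycarbonyl group would read alongside these three compounds.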